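Isopropoxycarbonyl in Place of Phenyl on the Chain

The source may report more compounds than this note shows. Statements on the series, on what has been measured and on what is new or still open speak of the compounds shown alone.

Of the compounds shown here, three that share a core have been measured in an ADME assay on the whole organism (plasma) for metabolic stability, with Rattus norvegicus as the target; on this read-out higher numbers stand for a longer-lived compound and lower numbers for a shorter-lived compound. Compound 1 (`C#CCCCC=C(c1cc(Br)c(OC)c(C(=O)OC)c1)c1cc(Br)c(OC)c(C(=O)OC)c1`) gives 0.315 h, compound 2 (`C=CCCCC=C(c1cc(Br)c(OC)c(C(=O)OC)c1)c1cc(Br)c(OC)c(C(=O)OC)c1`) gives 0.975 h, and compound 3 (`COC(=O)c1cc(C(=CCCCc2ccccc2)c2cc(Br)c(OC)c(C(=O)OC)c2)cc(Br)c1OC`) gives 0.917 h. Compound 3 therefore sits level with compound 2, and both lie clearly above compound 1.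

The next compound, compound 4 (`COC(=O)c1cc(C(=CCCCC(=O)OC(C)C)c2cc(Br)c(OC)c(C(=O)OC)c2)cc(Br)c1OC`), keeps the core and changes only the end of the chain: isopropoxycarbonyl in place of phenyl on a saturated chain carbon, three bonds along the chain from a double-bonded chain carbon.

Among the compounds with values here, three measured steps bear on this change, since each swaps the group at the same place. Vinyl in place of ethynyl gives a 3.1-fold higher number from compound 1 to compound 2 (0.49 log units; beyond the scatter), and phenyl in place of ethynyl gives a 2.9-fold higher number from compound 1 to compound 3 (0.46 log units; beyond the scatter). Both are modest. Phenyl in place of vinyl gives a 1.1-fold lower number from compound 2 to compound 3 (0.03 log units; within the scatter), which stays within the scatter. Within the data shown here, no measured compound carries isopropoxycarbonyl at this place, so these steps can guide only the likely size of the change, and the direction remains a judgement. The expected change in this assay is a 1.7-fold lower number from compound 3 to compound 4 (0.22 log units; within the scatter), a downward step no larger than the modest ones already seen. For compound 4 the estimated half-life is 0.55 h, with an expected range of 0.22 h to 1.3 h.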

Compound 4, half-life: 0.095 h
Compound 4: the middle estimate sits 5.8-fold (0.76 log units) above what was measured; the whole stated range lies above it.
By their numbers in this assay, from the lowest: compound 4; then compound 1; then compounds 3 and 2 (each within the scatter of the next).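

This result shows that the end of this chain can shift the half-life much further than the earlier swaps did: isopropoxycarbonyl in place of phenyl gives a 9.7-fold lower number from compound 3 to compound 4 (0.98 log units; beyond the scatter) in this assay, and in place of vinyl it gives a 10-fold lower number from compound 2 to compound 4 (1.01 log units; beyond the scatter), both larger than any step among the first three compounds. The new group also falls below ethynyl, previously the lowest of the groups at this place, with a 3.3-fold lower number from compound 1 to compound 4 (0.52 log units; beyond the scatter), so the order now runs from isopropoxycarbonyl through ethynyl up to phenyl and vinyl, which remain level with each other. Nothing available explains this drop or links it to any property of the group.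

As far as these compounds go, it remains open whether the lower number follows the carbonyl group itself or the isopropyl end attached to it, a question that a methoxycarbonyl group, an amide or a carboxylic acid at the same place could help to settle. The compounds shown also leave open whether isopropoxycarbonyl would give a similar number on a longer chain.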